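The source may hold more compounds than are shown below. What is called first, only, known or untested is meant among the compounds shown, and "the series" means these compounds.

Measured in a functional assay on MCF7 cells (Homo sapiens) for antiproliferative activity, read by MTT assay, with a stated time of 72 h; a lower number here means a stronger inhibitor, a higher number a weaker inhibitor:

compound 1, `C/C(C#Cc1ccccc1)=N\N/C(N)=N/S(=O)(=O)c1cc(C)c(Cl)cc1SCc1ccccc1`: 110000 nM
compound 2, `C/C(C#Cc1ccccc1)=N\N/C(N)=N/S(=O)(=O)c1cc(C)c(Cl)cc1SCc1cccc(C)c1`: 130000 nM
compound 3, `C/C(C#Cc1ccccc1)=N\N/C(N)=N/S(=O)(=O)c1cc(C)c(Cl)cc1SCc1ccccc1Cl`: 114000 nM

All three compounds share one core and differ only in the group carried on the saturated chain carbon bound to a sulfur. Compound 3 sits among the other two: the step of a 1.0-fold higher number from compound 1 to compound 3 (0.02 log units; within the scatter) and the step of a 1.1-fold lower number from compound 2 to compound 3 (0.06 log units; within the scatter) are both within the scatter, as is a 1.2-fold higher number from compound 1 to compound 2 (0.07 log units; within the scatter). None of the three changes at that position moved the number beyond noise.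

Compound 4, `C/C(C#Cc1ccccc1)=N\N/C(N)=N/S(=O)(=O)c1cc(C)c(Cl)cc1SCc1cccc2ccccc12`, has not yet been measured in this assay. Its difference from compound 3 is naphthalen-1-yl in place of 2-chlorophenyl on a saturated chain carbon bound to a sulfur. Among the measured compounds shown here, the three measured steps all bear on this same position, and each was within the scatter; the change to compound 4 is a larger one than any of them, a two-ring group in place of a one-ring group, so the data give no step of this kind to lean on directly. Compound 4 is therefore expected to show no step beyond the scatter, with a 1.0-fold higher number from compound 3 to compound 4 (0.00 log units; within the scatter) as the estimated change. The estimate for compound 4 is 115000 nM, with a range from 55000 nM to 240000 nM.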

Compound 4, half-maximal inhibitory concentration: 210000 nM
Beside the measured number, compound 4's estimate is 1.8-fold (0.26 log units) below it, and the stated range covers the measured number.
By their numbers in this assay, from the lowest: compounds 1, 3, 2 and 4 (each within the scatter of the next).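

In this assay, the step to the two-ring naphthalen-1-yl group is a 1.8-fold higher number from compound 3 to compound 4 (0.27 log units; within the scatter) and, against the other two one-ring groups, a 1.6-fold higher number from compound 2 to compound 4 (0.21 log units; within the scatter) and a 1.9-fold higher number from compound 1 to compound 4 (0.28 log units; within the scatter). The earlier compounds had shown only one-ring groups on the saturated chain carbon bound to a sulfur, and all four compounds now lie within the scatter of the next, so even this larger change to a second aromatic ring gives no step beyond the scatter. No supporting measurement is available to explain these numbers.

The compounds shown leave open whether a group of another kind on this carbon, such as an amine, a carboxylic acid or a longer alkyl chain, would give a step beyond the scatter. They also leave open whether any change away from this position, in the shared core, would do so.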